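The source may hold more compounds than are shown below. What is called first, only, known or untested is meant among the compounds shown, and "the series" means these compounds.

Series notes. Compound 1 `CC(=O)N/N=C/c1c(Cl)n(C2O[C@H](CO)[C@@H](O)[C@H]2O)c2cc(Cl)c(Cl)cc12` gives 9000 nM in a functional assay on KB cells (Homo sapiens) for cytotoxicity, read by spectrophotometry and crystal violet staining; on this read-out lower numbers stand for stronger inhibition and higher numbers for weaker inhibition. Within the data shown here, compound 2 `CO/N=C/c1c(Cl)n(C2O[C@H](CO)[C@@H](O)[C@H]2O)c2cc(Cl)c(Cl)cc12` gives 70000 nM in this assay and so stands as the highest of the two numbers measured; the only measured step, a 7.8-fold higher number from compound 1 to compound 2 (0.89 log units; beyond the scatter), separates the two.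

Compound 3 `NC(=O)c1c(Cl)n(C2O[C@H](CO)[C@@H](O)[C@H]2O)c2cc(Cl)c(Cl)cc12` differs from compound 2 by a group of 3 heavy atoms (1 carbon, 1 nitrogen, 1 oxygen; no ring) in place of a group of 4 heavy atoms (2 carbon, 1 nitrogen, 1 oxygen; no ring), on an aromatic carbon. Among the measured compounds shown here, no measured step covers this exchange: the step from compound 1 to compound 2 alters only the group on the double-bonded nitrogen, not the whole appendage on the aromatic carbon. What that step does show is that this position moves the number in this assay by a modest amount, so a change of similar size in either direction is plausible, with a return toward the lower number of compound 1 as likely as a further rise.

For compound 3 the estimate in this assay is 20000 nM, range 4000 nM to 100000 nM, an expected step of a 3.5-fold lower number from compound 2 to compound 3 (0.54 log units; beyond the scatter).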

Compound 3, half-maximal inhibitory concentration: 45000 nM
Beside the measured number, compound 3's estimate is 2.3-fold (0.35 log units) below it; the measured number falls inside the stated range.
By their numbers in this assay, from the lowest: compound 1; then compounds 3 and 2 (each within the scatter of the next).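

In this assay, carbamoyl on this aromatic carbon cannot be told apart from the group of compound 2, with a 1.6-fold lower number from compound 2 to compound 3 (0.19 log units; within the scatter), even though carbamoyl brings a hydrogen-bond donor that the group it replaces lacks. Compound 1 stays apart from carbamoyl as well, with a 5.0-fold higher number from compound 1 to compound 3 (0.70 log units; beyond the scatter), so of the three groups shown at this position only the acetamido-bearing appendage of compound 1 gives a number set off from both others. Nothing available here bears on why the numbers fall this way.

Going by these compounds, whether an amine or a carboxylic acid on this aromatic carbon would sit with compound 1 or with compound 3 remains open. Also open, on these data alone, is whether a longer chain on the carbamoyl nitrogen would bring the number closer to that of compound 1.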